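Removing the methylsulfanyl group from a triazole amide

A few compounds are considered here, and "the series" means these few. Any claim that something is new, unique, unknown or untested is made for them only; others in the source may bear on it.

Of the compounds shown here, three sharing one core have been tested in a toxicity assay on Vero cells (Chlorocebus sabaeus) for inhibition; on this read-out higher numbers stand for an effect only at larger amounts of compound and lower numbers for an effect already at smaller amounts. Compound 1 `COc1cccc(NC(=O)c2nnn(Cc3cc(C)on3)c2N)c1` gives only a limit of the assay, > 50100 nM. Compound 2 `COc1cccc(NC(=O)c2nnn(Cc3ccc(-n4cccn4)cc3)c2N)c1` likewise gives only a limit, > 50100 nM. Compound 3 `COc1cccc(NC(=O)c2nnn(Cc3ccc(SC)cc3)c2N)c1` also stops at a limit, > 50100 nM. Because every value rests at the limit of > 50100 nM in this assay, at which 3 of the 3 values shown sit, compound 3 cannot be placed relative to its neighbours. The steps a step that the two limits leave unreadable from compound 1 to compound 3 and a step that the two limits leave unreadable from compound 2 to compound 3 are thus of unknown size. Compound 4 `COc1cccc(NC(=O)c2nnn(Cc3ccccc3)c2N)c1` differs from compound 3 by hydrogen in place of methylsulfanyl on an aromatic carbon. Among the compounds with values here, no measured step bears on this change, so no shift in this assay beyond the scatter can be foreseen. The expected value for compound 4 is 100000 nM, within 30000 nM to 400000 nM, most likely again a limit. The expected step is a step that the limit leaves unreadable from compound 3 to compound 4.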

Compound 4, half-maximal effective concentration: > 50100 nM
Compound 4 ended at the assay's limit (the forecaster's own chance of this, stated with the estimate: 85%); the middle value is on the limit's open side.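

Compound 4 stops at a limit just as compound 1, compound 2 and compound 3 do, so no step among these compounds can be read: the limit of > 50100 nM in this assay, at which 4 of the 4 values shown sit. The compounds shown leave open whether any change on the shared core alters the effect in this assay.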